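Stereoisomer series of a hydroxylated pipecolic acid core

This account rests on a few compounds, and the source may have more. Where it says the series, first, only, none or still open, it means among the compounds named here.

In an assay on isolated protein for inhibition of cytosolic endo-beta-N-acetylglucosaminidase (Homo sapiens), tested at 1000 uM (a higher number here means more inhibition at the concentration tested (going by the name of the read-out), a lower number less inhibition), compound 1 `O=C(O)[C@H]1NC[C@H](O)[C@H](O)[C@@H]1O` gives 26%, compound 2 `O=C(O)[C@H]1NC[C@H](O)[C@@H](O)[C@@H]1O` gives 43%, and compound 3 `O=C(O)[C@H]1NC[C@@H](O)[C@@H](O)[C@@H]1O` gives 28%. Compound 3 sits with compound 1 within the scatter and under compound 2, the step of a number 15 percentage points lower from compound 2 to compound 3 (beyond the scatter) being beyond the scatter. Compound 4 `O=C(O)[C@H]1NC[C@H](O)[C@@H](O)[C@H]1O` is not yet measured; (the two compounds have the same atoms and bonds and differ only in configuration as drawn: 2 of 4 stereo elements differ; a stereocentre at a saturated ring carbon is drawn R in compound 3 and S in compound 4; a stereocentre at a saturated ring carbon is drawn R in compound 3 and S in compound 4). The single-centre steps a number 17 percentage points higher from compound 1 to compound 2 (beyond the scatter) and a number 15 percentage points lower from compound 2 to compound 3 (beyond the scatter) were modest; the double-centre step a number 2 percentage points higher from compound 1 to compound 3 (within the scatter) was within the scatter. Compound 4 is therefore expected to move by a number 2 percentage points higher from compound 3 to compound 4 (within the scatter), a change within or just beyond the scatter in either direction. Compound 4 is estimated at 30%, between 15% and 50%, in this assay.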

Compound 4, a percentage reported as inhibition, at one concentration (the size of the read-out at that concentration, not a potency): 2.6%
Estimate against measurement, compound 4: 27.4 percentage points above; measured number below the stated range.
By their numbers in this assay, from the lowest: compound 4; then compounds 1 and 3 (each within the scatter of the next); then compound 2.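

In this assay, a change at a single stereocentre can carry a large step, a number 40.4 percentage points lower from compound 2 to compound 4 (beyond the scatter), where the earlier single-centre steps were modest, and this loss rests on configuration alone: the fact that compounds 2 and 4 differ only in the configuration as drawn. Two-centre changes also prove able to matter, with a number 25.4 percentage points lower from compound 3 to compound 4 (beyond the scatter) and a number 23.4 percentage points lower from compound 1 to compound 4 (beyond the scatter), although the earlier two-centre pair stayed within the scatter. Compound 4 has the lowest number of the four, with its steps to all the others beyond the scatter.

On these data alone, whether this dependence on configuration persists with a methyl ester or an amide in place of the carboxylic acid remains open. Potencies also remain open, as these readings come from a single concentration.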